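The source may report more compounds than this note shows. Statements on the series, on what has been measured and on what is new or still open speak of the compounds shown alone.

In a functional assay on NCI/ADR cells (Homo sapiens) for cytotoxicity, read by sulforhodamine B assay (a lower number here means a stronger inhibitor of growth, a higher number a weaker inhibitor of growth), compound 1 `CC1=CC[C@@H]([C@@](C)(O)CCCC(C)(C)NC(=S)N/N=C\c2ccc(C)cc2)CC1` gives 6510 nM, compound 2 `CC1=CC[C@@H]([C@@](C)(O)CCCC(C)(C)NC(=S)N/N=C\c2ccc(N(C)C)cc2)CC1` gives 25200 nM and compound 3 `CC1=CC[C@@H]([C@@](C)(O)CCCC(C)(C)NC(=S)N/N=C\c2cccc([N+](=O)[O-])c2)CC1` gives 6720 nM. Compound 3 therefore lies within the scatter of compound 1 and clearly under compound 2. Compound 4 `CC1=CC[C@@H]([C@@](C)(O)CCCC(C)(C)NC(=S)N/N=C\c2ccc([N+](=O)[O-])cc2)CC1` differs from it thus: 4-nitrophenyl in place of 3-nitrophenyl on a carbon with a double bond to nitrogen. Among the measured compounds shown here, no measured pair isolates this change. The nearest guide is a 1.0-fold higher number from compound 1 to compound 3 (0.01 log units; within the scatter), a swap of 4-methylphenyl for 3-nitrophenyl. The larger 3.9-fold higher number from compound 1 to compound 2 (0.59 log units; beyond the scatter) and a 3.8-fold lower number from compound 2 to compound 3 (0.57 log units; beyond the scatter) both involve the dimethylamino group, absent here. The expected step is none beyond the scatter in this assay: a 1.0-fold lower number from compound 3 to compound 4 (0.01 log units; within the scatter). For compound 4 the estimated value is 6500 nM, with an expected range of 3000 nM to 14000 nM.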

Compound 4, concentration for 50% growth inhibition: 12800 nM
Compound 4: middle estimate off by 2.0-fold (0.29 log units), on the low side, within the range that was stated.
By their numbers in this assay, from the lowest: compounds 1, 3, 4 and 2 (each within the scatter of the next, the first and the last beyond it).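

In this assay, 4-nitrophenyl in place of 3-nitrophenyl on a carbon with a double bond to nitrogen gives a step within the scatter (a 1.9-fold higher number from compound 3 to compound 4 (0.28 log units; within the scatter)), so the nitro isomers are not separated here. Compound 4 also lies within the scatter of both compound 1 (a 2.0-fold higher number from compound 1 to compound 4 (0.29 log units; within the scatter)) and compound 2 (a 2.0-fold lower number from compound 2 to compound 4 (0.29 log units; within the scatter)), although those two differ beyond it, so nitro does not sort clearly with methyl or dimethylamino. No measurement shown explains these numbers.

Going by these compounds, whether a nitrile or a carboxylic acid in place of nitro would separate from these compounds remains open.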